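Moving the methoxy group within the shared core series

The source may hold more compounds than are shown below. What is called first, only, known or untested is meant among the compounds shown, and "the series" means these compounds.

Measured so far:
compound 1, `O=C1/C(=C/c2ccccc2)NS(=O)(=O)c2ccccc21`: 1780 nM
compound 2, `COc1ccccc1/C=C1\NS(=O)(=O)c2ccccc2C1=O`: 1240 nM

Compound 1 gives 1780 nM in an assay for inhibition of Intestinal-type alkaline phosphatase (Homo sapiens), read by spectrophotometry, with stated times of 10 min and 20 min (on this read-out higher numbers stand for weaker inhibition and lower numbers for stronger inhibition), the higher of the two numbers recorded. Its nearest neighbour is compound 2, and the step of a 1.4-fold lower number from compound 1 to compound 2 (0.16 log units; within the scatter) lies within the scatter, so the two values cannot be ordered.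

Compound 3, `COc1cccc(/C=C2\NS(=O)(=O)c3ccccc3C2=O)c1`, is not yet measured. It differs from compound 1 in one place: methoxy in place of hydrogen on an aromatic carbon, with the methoxy sitting meta to a large group. Going by the values given here, the only measured step that bears on this change is the one from compound 1 to compound 2, which also introduces a methoxy on the same six-membered aromatic ring and produced a change within the scatter. Among the compounds with values here, no measured pair shows the effect of the exact placement used in compound 3.

On that basis the step of a 1.2-fold lower number from compound 1 to compound 3 (0.07 log units; within the scatter) is expected to stay within the scatter, with no direction that can be called. For compound 3 the estimate in this assay is 1500 nM, expected to fall between 700 nM and 3500 nM.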

Compound 3, half-maximal inhibitory concentration: 1040 nM
Estimate against measurement, compound 3: 1.4-fold (0.16 log units) above; low and high end bracket the measured number.
By their numbers in this assay, from the lowest: compounds 3, 2 and 1 (each within the scatter of the next).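

In this assay, methoxy in place of hydrogen, sitting meta to a large group on the six-membered aromatic ring of carbon only, gives a 1.7-fold lower number from compound 1 to compound 3 (0.23 log units; within the scatter) and so adds a second methoxy placement with no step beyond the scatter. Compound 2 at 1240 nM and compound 3 at 1040 nM lie within the scatter of each other, so these two methoxy placements on this ring cannot be ordered. No measurement bears on why the methoxy placements read this way.

It remains open whether any substituent at this position can move the number beyond the scatter in this assay, since methoxy is the only group shown here in place of hydrogen on this ring. A carboxylic acid or an amine in the place of the methoxy, or a longer chain such as ethoxy or butoxy, would show whether this position responds to a group other than methoxy.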